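Replacing the Carbonyl Substituent of Compound 2

The source may hold more compounds than are shown below. What is called first, only, known or untested is meant among the compounds shown, and "the series" means these compounds.

In a functional assay on HepG2 cells (Homo sapiens), read by MTT assay, with a stated time of 48 h (a lower number here means a stronger inhibitor, a higher number a weaker inhibitor), compound 1 `CCN(CC)CCCNC(=O)c1ccc(C(CC)(CC)c2ccc(OCC(O)C(C)(C)C)c(C)c2)n1CC` gives 1100 nM and compound 2 `CCn1c(C(=O)N(C)CC(=O)O)ccc1C(CC)(CC)c1ccc(OCC(O)C(C)(C)C)c(C)c1` gives 17100 nM, the higher of the two numbers, which makes compound 2 the weaker inhibitor of this pair. Going by the values given here, only one measured step is available: a 16-fold higher number from compound 1 to compound 2 (1.19 log units; beyond the scatter). This large step took place on the same carbonyl carbon and brought in the (carboxymethyl)(methyl)amino group.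

Compound 3 `CCn1c(C(=O)Oc2ccc(CCO)cc2)ccc1C(CC)(CC)c1ccc(OCC(O)C(C)(C)C)c(C)c1`, not yet measured, gives that group up again: a group of 10 heavy atoms (8 carbon, 2 oxygen; one six-membered aromatic ring of carbon only) in place of a group of 6 heavy atoms (3 carbon, 1 nitrogen, 2 oxygen; no ring), on a carbonyl carbon. Among the compounds with values here, its incoming group differs from the one in compound 1, so the step of a 16-fold higher number from compound 1 to compound 2 (1.19 log units; beyond the scatter) offers only a rough scale and no firm guide. A partial move back toward lower numbers therefore seems most likely. In this assay, the expected change is a 3.4-fold lower number from compound 2 to compound 3 (0.53 log units; beyond the scatter). The estimate for compound 3 is 5000 nM, with an expected range of 1200 nM to 20000 nM.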

Compound 3, half-maximal inhibitory concentration: > 50000 nM
Compound 3: only a limit was reported (the forecaster's own chance of this, stated with the estimate: 10%); at least 10-fold (1.00 log units) between middle value and limit.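

Compound 3 reaches only a limit, not a number: the limit of > 50000 nM in this assay, at which 1 of the 3 values shown sits. Even so, the step is readable in one direction: putting the group with the six-membered aromatic ring on the carbonyl carbon in place of (carboxymethyl)(methyl)amino gives an at least 2.9-fold higher number from compound 2 to compound 3 (0.46 log units; beyond the scatter), and the comparison with the (3-(diethylamino)propyl)amino group gives an at least 45-fold higher number from compound 1 to compound 3 (1.65 log units; beyond the scatter). Giving up the (carboxymethyl)(methyl)amino group is therefore not enough on its own to bring the number down at this position, and among these three compounds, compound 1 keeps the lowest number.

Going by these compounds, the true value of compound 3 stays unknown, so both steps have a minimum size but no known full size. The compounds shown also leave open whether a small amine such as dimethylamino, or a longer chain ending in a carboxylic acid, on this carbonyl carbon would fall closer to compound 1 or to compound 2.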